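A few compounds are considered here, and "the series" means these few. Any claim that something is new, unique, unknown or untested is made for them only; others in the source may bear on it.

Of the compounds shown here, two carry numbers so far. Compound 1 `O=C(CN1C(=O)/C(=C/c2ccc(-c3ccc(Cl)cc3)o2)SC1=S)NCc1ccc(C(F)(F)F)cc1` gives 170000 nM in a functional assay on REH cells (Homo sapiens) for cytotoxicity, read by MTT assay, with a stated time of 72 h; on this read-out lower numbers stand for stronger inhibition and higher numbers for weaker inhibition. Among the measured compounds shown here, compound 2 `COc1ccc(CNC(=O)CN2C(=O)/C(=C/c3ccc(-c4ccc(Cl)cc4)o3)SC2=S)cc1` gives 44000 nM in this assay and stands lowest of the two, the only measured step, a 3.9-fold lower number from compound 1 to compound 2 (0.59 log units; beyond the scatter), separating it from its one neighbour. Compound 3 `O=C(CN1C(=O)/C(=C/c2ccc(-c3ccc(Cl)cc3)o2)SC1=S)NCc1ccc(Br)cc1` has not yet been measured. It differs from compound 2 by bromo in place of methoxy on an aromatic carbon. For the measured compounds named here, the one step in hand alters the same aromatic carbon and so bears on this change: putting methoxy in place of trifluoromethyl there lowered the number, as a 3.9-fold lower number from compound 1 to compound 2 (0.59 log units; beyond the scatter) shows, and taking the methoxy away again in favour of bromo is expected to give back part of that step, a modest rise rather than no change. Compound 3 is therefore estimated at 80000 nM in this assay, within a range of 30000 nM to 250000 nM. This estimate means a step of a 1.8-fold higher number from compound 2 to compound 3 (0.26 log units; within the scatter).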

Compound 3, half-maximal inhibitory concentration: 75000 nM
For compound 3 the middle estimate is 1.1-fold (0.03 log units) above the measured one; measured number inside the range.
By their numbers in this assay, from the lowest: compounds 2 and 3 (each within the scatter of the next); then compound 1.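

On this aromatic carbon, para to a large group, bromo and methoxy cannot be told apart in this assay with a 1.7-fold higher number from compound 2 to compound 3 (0.23 log units; within the scatter) as the whole step between them. Trifluoromethyl now stands apart from two replacements rather than one: a 2.3-fold lower number from compound 1 to compound 3 (0.36 log units; beyond the scatter) joins a 3.9-fold lower number from compound 1 to compound 2 (0.59 log units; beyond the scatter) as a step beyond the scatter, so among the three groups shown here, only trifluoromethyl separates from the others. No measurement at hand accounts for these steps.

From the compounds shown here alone, how an amine or a carboxylic acid on this same carbon would read in this assay remains open. Also open, going by these compounds, is whether these steps would carry over if a longer chain replaced the benzyl group that holds this ring.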